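Swapping Bromine for Chlorine on the Aniline Ring

The source may report more compounds than this note shows. Statements on the series, on what has been measured and on what is new or still open speak of the compounds shown alone.

Compound 1 `COc1cc2ncnc(Nc3ccc(F)c(Cl)c3)c2cc1OCCCCC(=O)Nc1ccc(S(N)(=O)=O)cc1`: 5020 nM
Compound 2 `C#Cc1cccc(Nc2ncnc3cc(OC)c(OCCCCC(=O)Nc4ccc(S(N)(=O)=O)cc4)cc23)c1`: 17700 nM
Compound 3 `COc1cc2ncnc(Nc3cccc(Br)c3)c2cc1OCCCCC(=O)Nc1ccc(S(N)(=O)=O)cc1`: 9750 nM

In a functional assay on A-431 cells (Homo sapiens) for antiproliferative activity, read by MTT assay, with a stated time of 72 h (on this read-out higher numbers stand for weaker inhibition and lower numbers for stronger inhibition), compound 3 stands second highest of the three numbers. Its two neighbours are set by a 1.8-fold lower number from compound 2 to compound 3 (0.26 log units; within the scatter) and by a 1.9-fold higher number from compound 1 to compound 3 (0.29 log units; within the scatter), both within the scatter. Compound 4 `COc1cc2ncnc(Nc3cccc(Cl)c3)c2cc1OCCCCC(=O)Nc1ccc(S(N)(=O)=O)cc1` differs from compound 3 by chloro in place of bromo on an aromatic carbon. For the measured compounds named here, no measured step exchanges these two halogens. The steps that touch this part of the molecule are a 3.5-fold higher number from compound 1 to compound 2 (0.55 log units; beyond the scatter), beyond the scatter, and a 1.8-fold lower number from compound 2 to compound 3 (0.26 log units; within the scatter), within it; the latter, a halogen entering the same position, is the nearer in kind. Compound 4 is therefore expected to show no step beyond the scatter, a 1.1-fold lower number from compound 3 to compound 4 (0.06 log units; within the scatter). The estimate for compound 4 is 8500 nM, with a range from 3500 nM to 22000 nM.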

Compound 4, half-maximal inhibitory concentration: 30400 nM
Estimate against measurement, compound 4: 3.6-fold (0.55 log units) below; measured number outside the range, above it.
By their numbers in this assay, from the lowest: compounds 1, 3, 2 and 4 (each within the scatter of the next, the first and the last beyond it).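

In this assay this position proves sensitive to which halogen it carries: chloro in place of bromo gives a 3.1-fold higher number from compound 3 to compound 4 (0.49 log units; beyond the scatter) and so the two halogens are not interchangeable here. Chloro and ethynyl are not told apart, since a 1.7-fold higher number from compound 2 to compound 4 (0.23 log units; within the scatter) stays within the scatter. The fluoro of the 3-chloro-4-fluorophenyl group also counts, as hydrogen in its place gives a 6.1-fold higher number from compound 1 to compound 4 (0.78 log units; beyond the scatter) and that step lies beyond the scatter. From the compounds shown here alone, whether an amine or a methoxy group at this position would track chloro or bromo remains open. Nothing at hand gives a reason for the gap between the two halogens.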